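Replacing a Benzoxazolylsulfanyl Ketone with a Pyridinyloxy Ketone

A few compounds are considered here, and "the series" means these few. Any claim that something is new, unique, unknown or untested is made for them only; others in the source may bear on it.

Measured compounds:
Compound 1, `CC(C)c1cc(OCC(=O)[C@H](CC(=O)O)NC(=O)[C@@H](NC(=O)COc2cccc3ccccc23)C(C)C)no1`: > 200000 nM
Compound 2, `CC(C)[C@H](NC(=O)COc1cccc2ccccc12)C(=O)N[C@@H](CC(=O)O)C(=O)CSc1nc2ccccc2o1`: > 200000 nM

In a functional assay on Jurkat cells (Homo sapiens) for inhibition (a lower number here means a stronger inhibitor, a higher number a weaker inhibitor), compound 1 gives > 200000 nM, which is a limit of the assay and not a number. In this assay compound 2 likewise gives > 200000 nM, again only a limit. Compound 2 therefore stands at the edge of what this assay can report, together with compound 1, as the limit of > 200000 nM in this assay, at which 2 of the 2 values shown sit, shows. Within the data shown here, the only measured step at the same place, a step that the two limits leave unreadable from compound 1 to compound 2, cannot be read.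

Compound 3, `CC(C)[C@H](NC(=O)COc1cccc2ccccc12)C(=O)N[C@@H](CC(=O)O)C(=O)COc1ccccn1`, differs from compound 2 by (pyridin-2-yl)oxy in place of (1,3-benzoxazol-2-yl)sulfanyl on a saturated chain carbon bound to a carbonyl carbon. Among the measured compounds shown here, since the one step bearing on this position is unreadable and both measured compounds sit at the limit, no direction beyond the scatter can be expected from the data. Compound 3 is therefore estimated to give 250000 nM, within a range from 60000 nM to 1000000 nM. The estimated step is a step that the limit leaves unreadable from compound 2 to compound 3.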

Compound 3, half-maximal inhibitory concentration: > 200000 nM
Compound 3 ended at the assay's limit; the forecaster's own chance of this, stated with the estimate: 85%; the middle value lies beyond the limit too.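

In this assay compound 3 gives > 200000 nM, again a limit and not a number. None of the steps among compound 1, compound 2 and compound 3 can be read. The compounds shown leave open which group on this saturated chain carbon bound to a carbonyl carbon, if any, would give a measurable value in this assay.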